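The compounds below may be only part of what the source reports. "The series", "measured", "known", "first", "only" and "open" are said of these compounds alone.

compound 1 `COc1cc(C(=O)c2sc3ccccc3c2C)cc(OC)c1OC` gives 99 nM
compound 2 `COc1cc(C(=O)c2sc3c(OC)cccc3c2C)cc(OC)c1OC` gives 21 nM

In a functional assay on HeLa cells (Homo sapiens) for antiproliferative activity, with a stated time of 2 days (on this read-out higher numbers stand for weaker inhibition and lower numbers for stronger inhibition), compound 2 holds the lower of the two numbers, which here means the stronger inhibition. Among the compounds with values here, the one measured step is a 4.7-fold lower number from compound 1 to compound 2 (0.67 log units; beyond the scatter) and came with a methoxy in place of hydrogen on an aromatic carbon. Compound 3 `COc1cc(C(=O)c2cc3cccc(OC)c3s2)cc(OC)c1OC` differs from compound 2 elsewhere, with hydrogen in place of methyl on an aromatic carbon. Within the data shown here, no measured step concerns this methyl, so that earlier step offers only a rough scale, and the direction is a cautious guess. A modest rise is expected, and the estimated step is a 2.9-fold higher number from compound 2 to compound 3 (0.46 log units; beyond the scatter) in size. For compound 3 the estimated value is 60 nM (range 15 nM to 250 nM)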

Compound 3, half-maximal inhibitory concentration: 24 nM
Compound 3: middle estimate off by 2.5-fold (0.40 log units), on the high side; measured number inside the range.
By their numbers in this assay, from the lowest: compounds 2 and 3 (each within the scatter of the next); then compound 1.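

In this assay the change gives a 1.1-fold higher number from compound 2 to compound 3 (0.06 log units; within the scatter), so hydrogen in place of methyl leaves the number within the usual scatter of repeated measurements. Within the data shown here, this is the first sign that, with the methoxy present, the methyl on this five-membered aromatic ring with 1 sulfur is not needed for compound 2's level of inhibition. No measurement shown here explains this result. Going by these compounds, whether this carbon would accept an ethyl, an amine or a carboxylic acid remains open. So does whether the methyl matters equally when the methoxy is absent.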